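Removing the Sulfonamide Arm from a Triazole Lactone

The source may hold more compounds than are shown below. What is called first, only, known or untested is meant among the compounds shown, and "the series" means these compounds.

Three members of this series share a common lactone core carrying different triazole side chains. Compound 1 `CC(C)(C)OC(=O)N1CCN(C(=S)SCc2cn(C[C@H](O)[C@H]3OC(=O)C(OCc4ccccc4)=C3OCc3ccccc3)nn2)CC1` gives only the limit > 100000 nM in a functional assay on CFPAC-1 cells (Homo sapiens) for antiproliferative activity, read by MTT assay, with a stated time of 72 h; a higher number here means a weaker inhibitor, a lower number a stronger inhibitor. Compound 3 `COc1ccccc1-c1cn(C/C=C2\OC(=O)C(OCc3ccccc3)=C2OCc2ccccc2)nn1` likewise gives only the limit > 100000 nM in this assay. Among the measured compounds shown here, compound 2 `O=C1O[C@H]([C@@H](O)Cn2cc(CNS(=O)(=O)c3ccc(F)cc3)nn2)C(OCc2ccccc2)=C1OCc1ccccc1` is the one member with a number, giving 34700 nM in this assay, and it stands alone against (the limit of > 100000 nM in this assay, at which 2 of the 3 values shown sit). Compound 4 `O=C1O[C@H]([C@@H](O)Cn2ccnn2)C(OCc2ccccc2)=C1OCc1ccccc1` differs from compound 2 by hydrogen in place of (((4-fluorophenyl)sulfonyl)amino)methyl on an aromatic carbon. For the measured compounds named here, no step between two measured compounds is known here. Since compound 2 gives 34700 nM with the full side chain, a step to weaker inhibition, beyond the usual scatter, is expected once the large group is gone, as a 2.3-fold higher number from compound 2 to compound 4 (0.36 log units; beyond the scatter). Compound 4 is therefore expected at about 80000 nM, within 30000 nM to 200000 nM.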

Compound 4, half-maximal inhibitory concentration: > 100000 nM
Compound 4: only a limit was reported; the forecaster's own chance of this, stated with the estimate: 55%; middle value at least 1.2-fold (0.09 log units) from the limit.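

In this assay, compound 4 gives only a limit, > 100000 nM. Hydrogen in place of (((4-fluorophenyl)sulfonyl)amino)methyl on this aromatic carbon nevertheless gives a readable step, an at least 2.8-fold higher number from compound 2 to compound 4 (0.45 log units; beyond the scatter), so the group at this position matters for the activity of compound 2. Compound 2 remains the only compound shown with a number, and compound 4 joins the others at the limit: the limit of > 100000 nM in this assay, at which 3 of the 4 values shown sit.

Which part of the lost group matters stays open. So does whether a plain aminomethyl or a carboxylic acid on the same aromatic carbon would give a measurable value.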